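This account rests on a few compounds, and the source may have more. Where it says the series, first, only, none or still open, it means among the compounds named here.

Measured compounds:
Compound 1 `Cc1ccc(Oc2ccc(CC3SC(=O)NC3=O)cc2)cc1` gives 547 nM in a functional assay for agonist activity at Free fatty acid receptor 1 (Homo sapiens), read by FLIPR, in the presence of a further agent that is not named here; a lower number here means that less compound is needed, a higher number that more compound is needed for the effect.
Compound 2 `Cc1cccnc1Oc1ccc(CC2SC(=O)NC2=O)cc1` gives 1090 nM in this assay.
Compound 3 `O=C1NC(=O)C(Cc2ccc(Oc3ccc(Cl)cn3)cc2)S1` gives 1870 nM in this assay.

All three share the same core and differ only in the aromatic ring attached to the oxygen. Compound 3 has the highest number of the three: one of its steps is a 1.7-fold higher number from compound 2 to compound 3 (0.23 log units; within the scatter), which is within the scatter, while the other is a 3.4-fold higher number from compound 1 to compound 3 (0.53 log units; beyond the scatter), a modest but real difference.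

Compound 4 `O=C1NC(=O)C(Cc2ccc(Oc3ccccc3Cl)cc2)S1` has not yet been measured. The change from compound 3 is 2-chlorophenyl in place of 5-chloropyridin-2-yl on an oxygen on an aromatic ring. Among the compounds with values here, two of the earlier steps speak to this: a 2.0-fold higher number from compound 1 to compound 2 (0.30 log units; within the scatter) and a 3.4-fold higher number from compound 1 to compound 3 (0.53 log units; beyond the scatter) both swap a carbon-only ring for one containing a nitrogen, and both moved the number up, the second beyond the scatter. Compound 4 goes the opposite way, back to a carbon-only ring, so a lower number than compound 3 is expected, though the chlorine now sits on a different ring position than in any measured compound, which adds uncertainty. For compound 4 the expected step is a 2.1-fold lower number from compound 3 to compound 4 (0.32 log units; beyond the scatter). The estimate for compound 4 in this assay is 900 nM, with a likely range from 300 nM to 2700 nM.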

Compound 4, half-maximal effective concentration: 1190 nM
The estimate for compound 4 lay 1.3-fold (0.12 log units) below the measured number, within the range that was stated.
By their numbers in this assay, from the lowest: compounds 1, 2, 4 and 3 (each within the scatter of the next, the first and the last beyond it).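

In this assay, the return to a carbon-only ring does not separate the new compound from the pyridine it replaces: a 1.6-fold lower number from compound 3 to compound 4 (0.20 log units; within the scatter) stays within the scatter, and in this pair the chlorine's place changes along with the ring atoms. The 2-chlorophenyl group also cannot be told apart from 3-methylpyridin-2-yl, as a 1.1-fold higher number from compound 2 to compound 4 (0.04 log units; within the scatter) is within the scatter too. Having a carbon-only ring on the oxygen is therefore not enough to match compound 1, since a 2.2-fold higher number from compound 1 to compound 4 (0.34 log units; beyond the scatter) is a modest step beyond the scatter, so the two carbon-only rings, 4-methylphenyl and 2-chlorophenyl, do not behave alike here.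

Nothing available explains why these groups give the numbers they do, and no outside measurement bears on them. Still open, from the compounds shown here alone, is how a 4-chlorophenyl group, or a phenyl ring carrying an amine, would compare with the 4-methylphenyl of compound 1, which would help show whether the kind of group on the ring or its place matters more.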